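Quinoline-2-amide series: piperidine to ethylpiperazine swap

This account rests on a few compounds, and the source may have more. Where it says the series, first, only, none or still open, it means among the compounds named here.

The series shares one core, carrying an amide at one end and a cyclic amine at the other. Compound 1 `CCN1CCN(c2cc(C)c3cc(NC(=O)c4ccccc4Br)ccc3n2)CC1` gives 27500 nM in a functional assay on MCF7 cells (Homo sapiens) for antiproliferative activity, read by MTT assay, with a stated time of 72 h; on this read-out lower numbers stand for stronger inhibition and higher numbers for weaker inhibition. Compound 2 `Cc1cc(N2CCCCC2)nc2ccc(NC(=O)c3ccc(Cl)c(Cl)c3)cc12` gives 31100 nM in this assay; the two numbers sit within the scatter of one another, so no order between compound 1 and compound 2 can be read from them. Compound 3 `CCN1CCN(c2cc(C)c3cc(NC(=O)c4ccc(Cl)c(Cl)c4)ccc3n2)CC1` has not yet been run. It differs from compound 2 in one place: 4-ethylpiperazin-1-yl in place of piperidin-1-yl on an aromatic carbon. Going by the values given here, no measured pair in the set isolates this change, so the expected step of a 1.2-fold lower number from compound 2 to compound 3 (0.08 log units; within the scatter) in this assay is put at none beyond the scatter, because compound 1, which already carries the 4-ethylpiperazin-1-yl group, gives 27500 nM. For compound 3 the estimate in this assay is 26000 nM, with a range from 10000 nM to 70000 nM.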

Compound 3, half-maximal inhibitory concentration: 1380 nM
Compound 3: middle estimate off by 19-fold (1.28 log units), on the high side, outside the stated range (below it).
By their numbers in this assay, from the lowest: compound 3; then compounds 1 and 2 (each within the scatter of the next).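

In this assay, with the 3,4-dichlorophenyl amide held constant, 4-ethylpiperazin-1-yl in place of piperidin-1-yl on the aromatic carbon next to the ring nitrogen gives a 23-fold lower number from compound 2 to compound 3 (1.35 log units; beyond the scatter), and with 4-ethylpiperazin-1-yl held constant, 3,4-dichlorophenyl in place of 2-bromophenyl gives a 20-fold lower number from compound 1 to compound 3 (1.30 log units; beyond the scatter). Compound 1 and compound 2 each carry only one of these two groups and lie within the scatter of each other, so among these compounds the low number appears only where both groups occur together, in compound 3. Nothing available explains the size of either step.

The compounds shown leave open how the amine step behaves with a 2-bromophenyl amide. They also leave open how a morpholine or an unsubstituted piperazine would compare at this position, and whether a propyl chain could replace the ethyl group.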